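Removing One Methoxy Group: What the Numbers Suggest

This account rests on a few compounds, and the source may have more. Where it says the series, first, only, none or still open, it means among the compounds named here.

Three compounds sharing one core were tested in a functional assay on HCT-15 cells (Homo sapiens) for inhibition, read by sulforhodamine B assay, with a stated time of 48 h; on this read-out higher numbers stand for weaker inhibition of growth and lower numbers for stronger inhibition of growth. Compound 1 `Nc1cc(N)c2nc(-c3ccccc3)c(Oc3ccc(Cl)c(Cl)c3)nc2c1` gives 20000 nM. Compound 2 `COc1ccc(CNc2nc3cc(N)cc(N)c3nc2-c2ccccc2)cc1OC` gives 30200 nM, the highest number of the three, though its gap to compound 1 lies within the scatter. Compound 3 `COc1cc(CNc2nc3cc(N)cc(N)c3nc2-c2ccccc2)cc(OC)c1OC` gives 3240 nM, and the step of a 9.3-fold lower number from compound 2 to compound 3 (0.97 log units; beyond the scatter) is the only change among these that reaches beyond the scatter.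

Compound 4 `COc1ccc(CNc2nc3cc(N)cc(N)c3nc2-c2ccccc2)cc1` has not yet been measured. It differs from compound 2 by hydrogen in place of methoxy on an aromatic carbon. Among the measured compounds shown here, the one measured step that bears on this change is a 9.3-fold lower number from compound 2 to compound 3 (0.97 log units; beyond the scatter), where adding a methoxy group lowered the number; compound 4 moves the other way, taking a methoxy group off. For the measured compounds named here, no measured pair shows this removal directly, so the direction rests on that single step alone. Compound 4 is therefore expected to sit near compound 2 or somewhat higher, with a 1.3-fold higher number from compound 2 to compound 4 (0.12 log units; within the scatter) likely staying within the scatter. The estimate for compound 4 is 40000 nM, expected to fall between 15000 nM and 100000 nM.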

Compound 4, concentration for 50% growth inhibition: 15800 nM
Compound 4: the middle estimate sits 2.5-fold (0.40 log units) above what was measured, within the range that was stated.
By their numbers in this assay, from the lowest: compound 3; then compounds 4, 1 and 2 (each within the scatter of the next).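

In this assay, replacing the methoxy group with hydrogen on this carbon, ortho to a methoxy group and meta to a large group, turns 3,4-dimethoxyphenyl into 4-methoxyphenyl and gives a 1.9-fold lower number from compound 2 to compound 4 (0.28 log units; within the scatter) and so no change that can be told from repeat scatter. Among the compounds shown here, the only methoxy change seen before was an addition, a 9.3-fold lower number from compound 2 to compound 3 (0.97 log units; beyond the scatter) and that step reached beyond the scatter, whereas this removal shows that the methoxy group at this carbon can be lost without a clear effect on the number. Nothing measured here explains why these two methoxy changes differ in size. The compounds shown leave open whether a different group on this carbon, such as an amine, a carboxylic acid or a longer ethoxy chain, would move the number. They also leave open whether the methoxy group that remains in compound 4 matters in its own right.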